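This account rests on a few compounds, and the source may have more. Where it says the series, first, only, none or still open, it means among the compounds named here.

Measured compounds: compound 1, `NC(=O)C[C@H](NC(=O)c1ccc(C#Cc2ccccc2)cc1)C(=O)NO`, compound 2, `CSC[C@H](NC(=O)c1ccc(C#Cc2ccccc2)cc1)C(=O)NO`, and compound 3, `NC[C@H](NC(=O)c1ccc(C#Cc2ccccc2)cc1)C(=O)NO`.

In a physicochemical assay for solubility (a higher number here means a more soluble compound, a lower number a less soluble compound), compound 1 gives 61000 nM, compound 2 gives 2000 nM, and compound 3 gives 13000 nM, the second highest of the three numbers. Compound 4, `CC(C)C(NC(=O)c1ccc(C#Cc2ccccc2)cc1)C(=O)NO`, differs from compound 3 in that (a group of 8 heavy atoms (5 carbon, 1 nitrogen, 2 oxygen; no ring) in place of a group of 7 heavy atoms (3 carbon, 2 nitrogen, 2 oxygen; no ring), on an amide-type nitrogen). Going by the values given here, two measured steps bear on the change at this position: a 4.7-fold lower number from compound 1 to compound 3 (0.67 log units; beyond the scatter) and a 6.5-fold higher number from compound 2 to compound 3 (0.81 log units; beyond the scatter). Both are modest, and the replacement of amino by a group without a nitrogen at that position resembles the reverse of the second step. Compound 4 is therefore expected to give a modestly lower number than compound 3, with the step estimated as a 4.3-fold lower number from compound 3 to compound 4 (0.64 log units; beyond the scatter). For compound 4 the estimated value is 3000 nM, expected to lie between 1000 nM and 9000 nM.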

Compound 4, solubility: 7000 nM
Compound 4: middle estimate off by 2.3-fold (0.37 log units), on the low side, within the range that was stated.
By their numbers in this assay, from the lowest: compound 2; then compounds 4 and 3 (each within the scatter of the next); then compound 1.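

In this assay, placing 1-(hydroxycarbamoyl)-2-methylpropyl on the amide-type nitrogen gives a 1.9-fold lower number from compound 3 to compound 4 (0.27 log units; within the scatter), so this group without an amino nitrogen cannot be told apart from the group it replaces. Loss of the amino group therefore does not by itself bring the number down to that of the methylsulfanyl compound, as a 3.5-fold higher number from compound 2 to compound 4 (0.54 log units; beyond the scatter) shows. From the compounds shown here alone, how a carboxylic acid or a longer chain at this place would compare remains open. Nothing available explains these differences.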